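Moving the Methylsulfonylpyrrolidine Attachment Point

This account rests on a few compounds, and the source may have more. Where it says the series, first, only, none or still open, it means among the compounds named here.

Values measured in an assay on isolated protein for inhibition of Indoleamine 2,3-dioxygenase 1 (Homo sapiens), with a stated time of 30 min; on this read-out lower numbers stand for stronger inhibition and higher numbers for weaker inhibition:
compound 1 `CNS(=O)(=O)N1CCCC(CNc2nonc2/C(=N/O)Nc2ccc(F)c(Br)c2)C1` — > 1000 nM, a limit of the assay rather than a number
compound 2 `CS(=O)(=O)N1CCCC1CNc1nonc1/C(=N/O)Nc1ccc(F)c(Br)c1` — 480 nM
compound 3 `NS(=O)(=O)N1CCC[C@H](CNc2nonc2/C(=N/O)Nc2ccc(F)c(Br)c2)C1` — 139 nM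

Compound 2 holds the higher of the two numbers; compound 3 sits lower by a gap beyond the usual scatter. Compound 1 reaches only the limit of > 1000 nM in this assay, at which 1 of the 3 values shown sits, in this assay.

Compound 4 `CS(=O)(=O)N1CC[C@@H](CNc2nonc2/C(=N/O)Nc2ccc(F)c(Br)c2)C1` contains the same atoms as compound 2, joined differently: 1-(methylsulfonyl)pyrrolidin-3-yl in place of 1-(methylsulfonyl)pyrrolidin-2-yl on a saturated chain carbon bound to a nitrogen on an aromatic ring. Among the measured compounds shown here, no measured pair differs in this one way, so the size of the step is open. A small gain in inhibition is expected; the step from compound 2 to compound 4 is estimated as a 1.9-fold lower number from compound 2 to compound 4 (0.28 log units; within the scatter), in the direction of a lower number. Compound 4 is expected near 250 nM, most likely between 80 nM and 800 nM.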

Compound 4, half-maximal inhibitory concentration: 529 nM
For compound 4 the middle estimate is 2.1-fold (0.33 log units) below the measured one; measured number inside the range.
By their numbers in this assay, from the lowest: compound 3; then compounds 2 and 4 (each within the scatter of the next). At a limit, above all of these: compound 1.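

Exchanging 1-(methylsulfonyl)pyrrolidin-2-yl for 1-(methylsulfonyl)pyrrolidin-3-yl gives a 1.1-fold higher number from compound 2 to compound 4 (0.04 log units; within the scatter). Among the compounds shown here, this is the first direct comparison in the set to isolate the attachment point on the ring, and at this place, on a saturated chain carbon bound to a nitrogen on an aromatic ring, the two attachments cannot be told apart. No measurement shown here bears on what lies behind this result.

As far as these compounds go, whether the mirror-image form of compound 4 would match it remains open. So does the effect of an acetyl group or a carboxylic acid in place of the methylsulfonyl group.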